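The compounds below may be only part of what the source reports. "The series", "measured", "known", "first", "only" and "open" are said of these compounds alone.

Of the compounds shown here, three sharing one core have been measured in a physicochemical assay for solubility, in phosphate buffer, at pH 7.4; a lower number here means a less soluble compound, a higher number a more soluble compound. Compound 1 (`CCOC(=O)c1c(-c2ccccc2)[nH]c2cc(OC)ccc2c1=O`) gives > 100000 nM, which is a limit of the assay. Compound 3 (`CCOC(=O)c1c(-c2cccc(OC)c2)[nH]c2cc(OC)ccc2c1=O`), with a methoxy group, gives > 100000 nM, also a limit and no number. It therefore stands with compound 1 at the limit of > 100000 nM in this assay, at which 2 of the 3 values shown sit. For the measured compounds named here, compound 2 (`CCOC(=O)c1c(-c2cccc([N+](=O)[O-])c2)[nH]c2cc(OC)ccc2c1=O`), with a nitro group, gives 13000 nM, the only actual number so far.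

Compound 4 (`CCOC(=O)c1c(-c2cccc(C(F)(F)F)c2)[nH]c2cc(OC)ccc2c1=O`) has trifluoromethyl in place of methoxy on an aromatic carbon, meta to a large group (trifluoromethyl in place of methoxy on an aromatic carbon). Going by the values given here, two measured steps bear on this. Nitro in place of hydrogen gave an at least 7.6-fold lower number from compound 1 to compound 2 (0.88 log units; beyond the scatter), and methoxy in place of nitro gave an at least 7.6-fold higher number from compound 2 to compound 3 (0.88 log units; beyond the scatter). The third, a step that the two limits leave unreadable from compound 1 to compound 3, says nothing about size. Reading trifluoromethyl with nitro rather than methoxy is a judgement these data do not test, so the expectation stays loose. The expected change is an at least 5.0-fold lower number from compound 3 to compound 4 (0.69 log units; beyond the scatter), a modest fall. The estimated value for compound 4 is 20000 nM, within an expected range of 6000 nM to 80000 nM.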

Compound 4, solubility: 19000 nM
Beside the measured number, compound 4's estimate is 1.1-fold (0.02 log units) above it, within the range that was stated.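

In this assay this position now holds two groups that cannot be told apart, trifluoromethyl and nitro: replacing nitro gives a 1.5-fold higher number from compound 2 to compound 4 (0.16 log units; within the scatter) and stays within the scatter. Set against methoxy, trifluoromethyl gives an at least 5.2-fold lower number from compound 3 to compound 4 (0.72 log units; beyond the scatter) and set against hydrogen it gives an at least 5.2-fold lower number from compound 1 to compound 4 (0.72 log units; beyond the scatter) so that the fall seen with nitro is no longer confined to one group. Each of these two steps is bounded on one side only, since compound 1 and compound 3 are limits and not numbers: the limit of > 100000 nM in this assay, at which 2 of the 4 values shown sit.

Going by these compounds, what nitro and trifluoromethyl share that might set their values apart from those of hydrogen and methoxy remains open, since only these two groups give actual numbers here. An amine, a carboxylic acid or a chlorine atom at this position would show how far the pattern extends.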